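A few compounds are considered here, and "the series" means these few. Any claim that something is new, unique, unknown or untested is made for them only; others in the source may bear on it.

Measured so far:
Compound 1 `O=C(NNc1ccccc1F)c1ccccc1NS(=O)(=O)c1cnc(O)nc1O` gives 9610 nM in a functional assay on A549 cells (Homo sapiens) for antiproliferative activity, read by MTT assay, with a stated time of 24 h; a higher number here means a weaker inhibitor, a lower number a stronger inhibitor.
Compound 2 `Cc1ccccc1C(=O)NNC(=O)c1cccc(NS(=O)(=O)c2cnc(O)nc2O)c1` gives 8010 nM in this assay.

Compound 1 has the highest number of the two; compound 2 is the nearest, and the gap between them lies within the usual scatter, so no order can be read between them. For the measured compounds named here, both numbers sit in the same weak range, and the two structures differ in more than one place, so no single step can be isolated from them.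

Compound 3 `O=C(NNC(=O)c1ccccc1NS(=O)(=O)c1cnc(O)nc1O)c1cccc(Cl)c1` has not yet been measured. It differs from compound 1 in one place: (3-chlorophenyl)carbonyl in place of 2-fluorophenyl on an amine nitrogen. Going by the values given here, no pair of measured compounds shows this change, so its size is not known from the data. Since both measured compounds fall in the same weak range, the step of a 1.2-fold lower number from compound 1 to compound 3 (0.08 log units; within the scatter) is expected to be small, within the scatter, with no clear direction. Compound 3 is therefore expected to give 8000 nM, with a range from 3000 nM to 20000 nM.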

Compound 3, half-maximal inhibitory concentration: 1260 nM
Estimate against measurement, compound 3: 6.3-fold (0.80 log units) above, outside the stated range (below it).
By their numbers in this assay, from the lowest: compound 3; then compounds 2 and 1 (each within the scatter of the next).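

In this assay, the group on the amine nitrogen whose other neighbour is the amide-type nitrogen proves able to shift the number: (3-chlorophenyl)carbonyl in place of 2-fluorophenyl gives a 7.6-fold lower number from compound 1 to compound 3 (0.88 log units; beyond the scatter), a step beyond the scatter that compounds 1 and 2 alone could not reveal. The cut one bond further out reads (2-fluorophenyl)amino to ((3-chlorophenyl)carbonyl)amino, so a carbonyl enters with one hydrogen-bond acceptor, the halogen changes from fluorine to chlorine, and a six-membered aromatic ring of carbon only is present on both sides. Nothing at hand accounts for the size of this step.

For the compounds shown here, the single step does not separate the contribution of the carbonyl from that of the halogen, and (2-fluorophenyl)carbonyl at this place would be the direct test of the carbonyl alone. Also open, from the compounds shown here alone, is whether the aromatic ring is needed at all, for instance whether a plain acetyl group or a longer alkyl chain ending in a carboxylic acid would stay near compound 3 at 1260 nM or return to the weaker range of compound 1.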